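Working notes: pyridin-2-yl to pyridin-4-yl on the amine

The source may report more compounds than this note shows. Statements on the series, on what has been measured and on what is new or still open speak of the compounds shown alone.

Measured in a physicochemical assay for solubility, read by HPLC; on this read-out lower numbers stand for lower solubility and higher numbers for higher solubility:
- compound 1 `COc1ccc(NC[C@H](O)COc2ccc(N3C[C@H](CNC(C)=O)OC3=O)cc2F)cc1`: 56000 nM
- compound 2 `CC(=O)NC[C@H]1CN(c2ccc(OC[C@H](O)CNc3cc(C(F)(F)F)cc(C(F)(F)F)c3)c(F)c2)C(=O)O1`: 22000 nM
- compound 3 `CC(=O)NC[C@H]1CN(c2ccc(OC[C@H](O)CNc3ccccn3)c(F)c2)C(=O)O1`: 35100000 nM

Compound 3 stands highest of the three, beyond the scatter from both compound 1 and compound 2. The next compound, compound 4 `CC(=O)NC[C@H]1CN(c2ccc(OC[C@H](O)CNc3ccncc3)c(F)c2)C(=O)O1`, carries pyridin-4-yl in place of pyridin-2-yl on an amine nitrogen. Within the data shown here, no measured pair isolates this change, so the expectation starts from compound 3 at 35100000 nM and no step beyond the scatter is expected in this assay. The expected step of a 1.4-fold higher number from compound 3 to compound 4 (0.15 log units; within the scatter) is small, within the scatter. For compound 4 the estimate is 50000000 nM, with an expected range from 10000000 nM to 200000000 nM.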

Compound 4, solubility: 24600000 nM
For compound 4 the middle estimate is 2.0-fold (0.31 log units) above the measured one; low and high end bracket the measured number.
By their numbers in this assay, from the lowest: compound 2; then compound 1; then compounds 4 and 3 (each within the scatter of the next).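

In this assay, among these compounds, pyridin-4-yl in place of pyridin-2-yl on the amine nitrogen gives a 1.4-fold lower number from compound 3 to compound 4 (0.15 log units; within the scatter), the first step that isolates a single change. On this read-out, the two pyridine isomers are not separated at this position. Nothing further measured bears on this result.

Open, as far as these compounds go, is whether pyridin-3-yl or pyrimidin-2-yl on the same amine nitrogen would read alike with compound 3 and compound 4. Also open, from the compounds shown here alone, is whether a methyl group on that nitrogen would leave the reading unchanged.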